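Working notes: from compound 2 to compound 4

This account rests on a few compounds, and the source may have more. Where it says the series, first, only, none or still open, it means among the compounds named here.

compound 1 (`COc1ccc(COc2ccc(C3CN(C(=O)c4cc(OCCO)ccn4)C3)cc2OC)cc1`) 5600 nM
compound 2 (`COc1cc(C2CN(C(=O)c3cc(OC[C@@H](O)CO)ccn3)C2)ccc1OCc1ccc(C2CC2)cc1`) 3100 nM
compound 3 (`CCc1ccc(COc2ccc(C3CN(C(=O)c4cc(COC[C@@H](O)CO)ccn4)C3)cc2OC)cc1`) 7100 nM

In a physicochemical assay for solubility, in phosphate buffer, at pH 7.2 (on this read-out lower numbers stand for lower solubility and higher numbers for higher solubility), compound 2 gives 3100 nM and stands within the scatter of compound 1 (5600 nM). Compound 3 (7100 nM) lies beyond the scatter from compound 2, with the higher number.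

Compound 4 (`COc1cc(C2CN(C(=O)c3cc(COCC(CO)(CO)CO)ccn3)C2)ccc1OCc1ccc(C2CC2)cc1`) differs from compound 2 in one place: (3-hydroxy-2,2-bis(hydroxymethyl)propoxy)methyl in place of 2,3-dihydroxypropoxy on an aromatic carbon. Among the measured compounds shown here, no two measured compounds differ in one place only, so no measured step speaks directly to this change. The expectation rests only on the span of the three values in this assay, which runs from compound 2 (3100 nM) to compound 3 (7100 nM) and barely exceeds the scatter. A small upward step is expected, one that stays within the scatter. The expected change is a 1.6-fold higher number from compound 2 to compound 4 (0.21 log units; within the scatter) (an estimate, with wide uncertainty). For compound 4 the estimated value is 5000 nM (expected range 2000 nM to 12000 nM).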

Compound 4, solubility: 1500 nM
Compound 4: middle estimate off by 3.3-fold (0.52 log units), on the high side; the whole stated range lies above it.
By their numbers in this assay, from the lowest: compound 4; then compounds 2, 1 and 3 (each within the scatter of the next, the first and the last beyond it).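

Among the compounds shown here, this is the first step that can be read at one place, and in the read-out used here (this assay) it gives (a 2.1-fold lower number from compound 2 to compound 4 (0.32 log units; beyond the scatter)). On the aromatic carbon opposite the ring nitrogen, (3-hydroxy-2,2-bis(hydroxymethyl)propoxy)methyl in place of 2,3-dihydroxypropoxy raises the counts of hydrogen-bond donors and acceptors, yet the number does not rise with them, so at this position those counts alone do not set the value. No measurement at hand accounts for the step.

Still open, on these data alone, is which part of the change carries the step, since the link to the ring and the size of the chain change together. Also open, as far as these compounds go, is how an amine or a carboxylic acid at this position would read in the same assay (this assay).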